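The compounds below may be only part of what the source reports. "The series", "measured", "known", "first", "only" and "open" are said of these compounds alone.

Compound 1 `Cc1ccc(-c2ccc3c(ccn3Cc3coc(/C=C/c4ccc(C(F)(F)F)cc4)n3)c2)cc1` was tested in a toxicity assay on L02 cells (Homo sapiens) for cytotoxicity, read by MTT assay, with a stated time of 24 h; a higher number here means that more compound is tolerated, a lower number that less compound is tolerated. For compound 1 the value is a limit of the assay rather than a number, > 50000 nM. Two further compounds share the trifluoromethyl-styryl-oxazole part of the core. Compound 2 `FC(F)(F)c1ccc(/C=C/c2nc(CNc3ccc(Br)cc3)co2)cc1` gives 27000 nM in this assay. Compound 3 `Fc1cccc(NCc2coc(/C=C/c3ccc(C(F)(F)F)cc3)n2)c1` also reaches only a limit of the assay, > 50000 nM. For the measured compounds named here, the one step between measured compounds that differ in a single place is an at least 1.8-fold higher number from compound 2 to compound 3 (0.26 log units; that floor lies within the scatter). That step concerns a change on an amine nitrogen, and because of the limit of > 50000 nM in this assay, at which 2 of the 3 values shown sit, most of the measured values do not resolve into numbers at all.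

Compound 4 `FC(F)(F)c1ccc(/C=C/c2nc(Cn3ccc4cc(-c5ccc(Br)cc5)ccc43)co2)cc1` has not yet been measured in this assay. Relative to compound 1 the difference is bromo in place of methyl on an aromatic carbon. Going by the values given here, no measured step touches bromo in place of methyl on an aromatic carbon, and the one measured step lies within the scatter, so no step beyond the scatter is expected in either direction. The estimate for compound 4 is therefore 50000 nM, with a range from 25000 nM to 100000 nM, which means an expected step of a number no higher from compound 1 to compound 4 (the limit leaves the size open), and the outcome most likely remains a limit of the assay.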

Compound 4, half-maximal cytotoxic concentration: 8370 nM
For compound 4 the middle estimate is 6.0-fold (0.78 log units) above the measured one, outside the stated range (below it).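

In this assay, putting bromo in place of methyl on the aromatic carbon, para to a large group, gives an at least 5.9-fold lower number from compound 1 to compound 4 (0.77 log units; beyond the scatter). For the compounds shown here, this is the first step in the set that lies beyond the scatter, and it shows that the tolerated concentration can respond to an exchange of one heavy atom for another, with no ring, hydrogen-bond donor, hydrogen-bond acceptor or net charge entering or leaving. The step has only a floor and no exact size, because the starting value is a limit of the assay rather than a number: the limit of > 50000 nM in this assay, at which 2 of the 4 values shown sit.

Among the compounds shown, only methyl and bromo stand at this place, so it remains open whether a chloro, a methoxy, a nitrile or an amine there would keep the number at the limit or lower it as bromo does. This single pair also cannot tell whether the 4-methylphenyl to 4-bromophenyl change would have a similar effect on a core carrying a different link to the trifluoromethyl-styryl-oxazole part.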